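The compounds below may be only part of what the source reports. "The series", "measured", "known", "first", "only" and "open" are said of these compounds alone.

Measured so far in an ADME assay on Vero cells (Chlorocebus sabaeus) for cytotoxicity, with a stated time of 72 h; a higher number here means a weaker inhibitor, a lower number a stronger inhibitor:
Compound 1 `CCOC(=O)c1cc(-c2cccc(OCc3cccc(F)c3)c2)on1` gives > 128000 nM, a limit of the assay.
Compound 2 `CCOC(=O)c1cc(-c2cccc(OCc3cccc(Cl)c3)c2)on1` gives > 128000 nM, a limit of the assay.
Compound 3 `CCOC(=O)c1cc(-c2cccc(OCc3cccc(C)c3)c2)on1` gives > 128000 nM, a limit of the assay.

Compound 3 stands at a limit, and the two other values shown are limits too, so no order among the three can be read. Every measured step is unreadable: a step that the two limits leave unreadable from compound 1 to compound 2, a step that the two limits leave unreadable from compound 1 to compound 3 and a step that the two limits leave unreadable from compound 2 to compound 3 all run between limits because of the limit of > 128000 nM in this assay, at which 3 of the 3 values shown sit.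

Compound 4 `CCOC(=O)c1cc(-c2cccc(OCc3ccc(F)c(F)c3)c2)on1` differs from compound 3 by 3,4-difluorophenyl in place of 3-methylphenyl on a saturated chain carbon bound to an oxygen on an aromatic ring. The measured steps bear on it only in that earlier swaps on the saturated chain carbon bound to an oxygen on an aromatic ring never moved a value off the limit. Compound 4 is therefore expected to stay at the limit, the expected step of a number no higher from compound 3 to compound 4 (the limit leaves the size open) meaning no change beyond the scatter. The estimate for compound 4 is 128000 nM, between 60000 nM and 300000 nM, most likely reported as a limit.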

Compound 4, half-maximal inhibitory concentration: > 128000 nM
Compound 4 ended at the assay's limit; the forecaster's own chance of this, stated with the estimate: 85%; the middle value lies on the limit itself.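

In this assay no new step can be read, since compound 4, like compound 1, compound 2 and compound 3, sits at a limit: the limit of > 128000 nM in this assay, at which 4 of the 4 values shown sit.

The compounds shown leave open how far each of the four lies from that limit, and whether their ring substituents differ at all in this read-out.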